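Butyl to 4-fluorophenyl on an aromatic nitrogen

This account rests on a few compounds, and the source may have more. Where it says the series, first, only, none or still open, it means among the compounds named here.

Measured so far in a functional assay on HeLa cells (Homo sapiens) for antiproliferative activity, read by MTT assay, with a stated time of 72 h; a higher number here means a weaker inhibitor, a lower number a stronger inhibitor
- compound 1 `CCCCn1ccnc1-c1cc(OC)c(OC)c(OC)c1` gives only a limit, > 100000 nM
- compound 2 `COc1cc(-c2nccn2-c2ccc3sccc3c2)cc(OC)c1OC` gives 1400 nM
- compound 3 `COc1cc(-c2nccn2-c2cccc([N+](=O)[O-])c2)cc(OC)c1OC` gives 6700 nM

Compound 1 is known only through the limit of > 100000 nM in this assay, at which 1 of the 3 values shown sits, and has no number. Compound 4 `COc1cc(-c2nccn2-c2ccc(F)cc2)cc(OC)c1OC` carries 4-fluorophenyl in place of butyl on an aromatic nitrogen. Compound 2 gives 1400 nM and compound 3 gives 6700 nM with an aromatic ring on that nitrogen, so a large step toward stronger inhibition is expected in this assay for this change. The estimated at least 20-fold lower number from compound 1 to compound 4 (1.30 log units; beyond the scatter) stays approximate while only a limit is available as its start. Compound 4 is expected at 5000 nM within an estimated range from 1000 nM to 30000 nM in this assay.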

Compound 4, half-maximal inhibitory concentration: 17500 nM
Compound 4: middle estimate off by 3.5-fold (0.54 log units), on the low side; measured number inside the range.
By their numbers in this assay, from the lowest: compound 2; then compound 3; then compound 4. At a limit, above all of these: compound 1.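

In this assay, compound 1 gives only a limit, > 100000 nM. From the compounds shown here alone, with 4-fluorophenyl in place of butyl on an aromatic nitrogen, the series shows an at least 5.7-fold lower number from compound 1 to compound 4 (0.75 log units; beyond the scatter), a step whose true size stays open at its starting end: the limit of > 100000 nM in this assay, at which 1 of the 4 values shown sits. An aromatic ring at this position does not fix the level by itself: compound 4 gives 17500 nM, compound 3 gives 6700 nM and compound 2 gives 1400 nM.

Still open, going by these compounds, is how a benzyl group or a pyridyl ring on this nitrogen would read in this assay.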